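The source may hold more compounds than are shown below. What is called first, only, known or untested is meant among the compounds shown, and "the series" means these compounds.

Measured in a functional assay on HCT-116 cells (Homo sapiens) for inhibition, read by MTT assay, with a stated time of 48 h; on this read-out higher numbers stand for weaker inhibition and lower numbers for stronger inhibition:
compound 1 `COc1ccc(CN(C(C)=O)c2cc(OC)c(OC)c(OC)c2)cc1O` gives 270 nM
compound 2 `COc1ccc(CNc2cc(OC)c(OC)c(OC)c2)cc1Cl` gives 41700 nM
compound 3 `COc1ccc(CNc2cc(OC)c(OC)c(OC)c2)cc1C` gives 60900 nM

Compound 1 has the lowest number of the three; compound 2 and compound 3 both lie far higher, beyond the scatter. For the measured compounds named here, the one step available, a 1.5-fold higher number from compound 2 to compound 3 (0.16 log units; within the scatter), concerns an aromatic substituent on two compounds that lack the acetyl on the amide-type nitrogen of compound 1 and says nothing about the carbonyl carbon. Compound 4 `COc1ccc(CN(C(=O)/C=C/CBr)c2cc(OC)c(OC)c(OC)c2)cc1O` differs from compound 1 by 3-bromoprop-1-en-1-yl in place of methyl on a carbonyl carbon. Going by the values given here, no measured pair changes the acetyl, so the direction is open; the shared core of compound 1 is kept, and the expectation is a step within the scatter. For compound 4 in this assay the estimate is 200 nM, range 40 nM to 1000 nM, an expected step of a 1.4-fold lower number from compound 1 to compound 4 (0.13 log units; within the scatter).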

Compound 4, half-maximal inhibitory concentration: 59 nM
Compound 4: middle estimate off by 3.4-fold (0.53 log units), on the high side; the measured number falls inside the stated range.
By their numbers in this assay, from the lowest: compound 4; then compound 1; then compounds 2 and 3 (each within the scatter of the next).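

Working from the carbonyl carbon on the amide-type nitrogen, the series tolerates a longer, unsaturated, bromine-bearing group: in this assay, 3-bromoprop-1-en-1-yl in place of methyl gives a 4.6-fold lower number from compound 1 to compound 4 (0.66 log units; beyond the scatter). For the compounds shown here, this is the first read on this position, as the earlier step concerned only an aromatic substituent. Nothing at hand bears on the reason for this step.

Open, as far as these compounds go, is whether the bromine, the double bond or the added chain length carries the step. A saturated 3-bromopropyl group, a prop-1-en-1-yl group without bromine, or an amine in place of the bromine would help separate these.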